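Swapping the Pyrazolyl Ring for Isopropyl on the Amide Nitrogen

The compounds below may be only part of what the source reports. "The series", "measured", "known", "first", "only" and "open" are said of these compounds alone.

Measured so far in an assay on HEK293 cells for agonist activity at transient receptor potential cation channel subfamily M member 8 (Homo sapiens), read by fluorescence and calcium flux, with a stated time of 15 min; a lower number here means that less compound is needed, a higher number that more compound is needed for the effect: compound 1 `CCN(Cc1cccs1)C(=O)COc1ccc(C)cc1` gives 8 nM, and compound 2 `Cc1ccc(OCC(=O)N(Cc2cccs2)c2ccnn2C)cc1` gives 422 nM.

For the measured compounds named here, compound 2 stands at the higher of the two numbers, so more of it is needed for the effect; its only neighbour is compound 1, and the change between them is a 53-fold higher number from compound 1 to compound 2 (1.72 log units; beyond the scatter). Going by the values given here, that step is the one directly relevant guide. It shows what happens when a small alkyl group on the amide-type nitrogen is exchanged for the 1-methyl-1H-pyrazol-5-yl ring.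

Compound 3 `Cc1ccc(OCC(=O)N(Cc2cccs2)C(C)C)cc1` differs from compound 2 in just one place: isopropyl in place of 1-methyl-1H-pyrazol-5-yl on an amide-type nitrogen. This largely reverses the earlier exchange, putting a small alkyl back where compound 1 carried ethyl. Isopropyl is not ethyl, so the return need not be complete, but a clear drop in the number is expected, on the order of a 28-fold lower number from compound 2 to compound 3 (1.45 log units; beyond the scatter).

Compound 3 is therefore estimated at 15 nM in this assay, with a likely range from 4 nM to 60 nM.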

Compound 3, half-maximal effective concentration: 70 nM
Compound 3: middle estimate off by 4.7-fold (0.67 log units), on the low side; measured number above the stated range.
By their numbers in this assay, from the lowest: compound 1; then compound 3; then compound 2.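

In this assay, exchanging the 1-methyl-1H-pyrazol-5-yl ring for isopropyl on the amide-type nitrogen gives a 6.0-fold lower number from compound 2 to compound 3 (0.78 log units; beyond the scatter), so removing the ring wins back only part of the earlier loss. The remaining gap appears as an 8.8-fold higher number from compound 1 to compound 3 (0.94 log units; beyond the scatter), which comes from methyl in place of hydrogen on the saturated chain carbon bound to the amide-type nitrogen, so this position responds to a small change within the alkyl groups and not only to the large exchange of alkyl for ring. The three groups therefore give three separate results, with ethyl in compound 1 needing the least compound, then isopropyl in compound 3, then the ring in compound 2, though nothing measured here bears on why they fall in this order.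

Still open, as far as these compounds go, is whether a longer chain such as n-propyl, or a small cyclopropyl ring, would match ethyl or follow isopropyl upward, which would show whether ethyl lies near the best size for this position. Also open, from the compounds shown here alone, is whether a ring with only carbon atoms, such as phenyl, would behave like the 1-methyl-1H-pyrazol-5-yl ring.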